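Replacing the vinyl of compound 3 with a sulfur-bearing chain

The source may report more compounds than this note shows. Statements on the series, on what has been measured and on what is new or still open speak of the compounds shown alone.

Measured so far:
compound 1 `Nc1ccc2nc(N)sc2c1`, > 10 mg/kg
compound 2 `Nc1nc2ccc(C3CCCCC3)cc2s1`, > 10 mg/kg
compound 3 `C=CCn1c(=N)sc2cc(OC(F)(F)F)ccc21`, 7 mg/kg

All three compounds were tested in a functional assay on the whole organism with Rattus norvegicus as the target; on this read-out higher numbers stand for an effect only at larger amounts of compound and lower numbers for an effect already at smaller amounts. Compound 1 gives > 10 mg/kg, which is a limit of the assay and not a number. Compound 2 likewise gives > 10 mg/kg, again a limit. Within the data shown here, compound 3 is the one compound with a measured value, 7 mg/kg. Two of the three values sit at the limit (the limit of > 10 mg/kg in this assay, at which 2 of the 3 values shown sit), so compound 3 is the only fixed point available.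

Compound 4 `CSCCn1c(=N)sc2cc(OC(F)(F)F)ccc21` is not yet measured. It differs from compound 3 in one place: (methylsulfanyl)methyl in place of vinyl on a saturated chain carbon bound to an aromatic nitrogen. Among the measured compounds shown here, because no pair of measured compounds differs in a single place, the data give no measured step to lean on, and the size of this change can only be guessed. The expectation is a step of a 1.3-fold higher number from compound 3 to compound 4 (0.11 log units; within the scatter), which is estimated to stay within the usual scatter. Compound 4 is therefore expected to give about 9 mg/kg, likely between 3.5 mg/kg and 25 mg/kg.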

Compound 4, dose for half-maximal effect: 1 mg/kg
For compound 4 the middle estimate is 9.0-fold (0.95 log units) above the measured one; the measured number lies below the stated range.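

In this assay, changing allyl to 2-(methylsulfanyl)ethyl on the aromatic nitrogen gives a 7.0-fold lower number from compound 3 to compound 4 (0.85 log units; beyond the scatter), so a sulfur-bearing chain at this place brings the effect to smaller amounts of compound. The earlier compounds shown here could not show this, since no two of them formed a pair differing in one place, and the values of compound 1 and compound 2 are limits rather than numbers: the limit of > 10 mg/kg in this assay, at which 2 of the 4 values shown sit. This single step changes two things together, as a double bond leaves and a sulfur atom enters, and the result cannot tell these apart.

A methoxyethyl chain, with oxygen in place of sulfur, or a plain butyl chain would be needed to separate them. As far as these compounds go, how a longer chain such as 3-(methylsulfanyl)propyl, or an amine on the chain, would read in this assay also stays open.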